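A few compounds are considered here, and "the series" means these few. Any claim that something is new, unique, unknown or untested is made for them only; others in the source may bear on it.

Of the compounds shown here, three have been measured in an in vitro assay on BTI-TN-5B1-4 cells for inhibition of Amine oxidase [flavin-containing] A (Homo sapiens), read by fluorescence; a higher number here means a weaker inhibitor, a lower number a stronger inhibitor. Compound 1 `N#Cc1c(F)c(F)c(NC(=O)c2cc3ccccc3oc2=O)c(F)c1F` gives 16000 nM, and compound 2 `O=C(Nc1c(F)c(F)nc(F)c1F)c1cc2ccccc2oc1=O` gives 11400 nM. Compound 3 `CC(C)NC(=O)c1cc2ccc(OCc3ccccc3)cc2oc1=O` gives 63500 nM, the highest of the three numbers; the gap to compound 1 and the larger gap to compound 2 both lie beyond the scatter, so compound 3 is the weakest inhibitor among them. Among the measured compounds shown here, compound 3 differs from compound 1 and from compound 2 in more than one place, so no single step between measured compounds can be read from these values.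

Compound 4 `COc1cc(NC(=O)c2cc3ccc(OCc4ccccc4)cc3oc2=O)cc(OC)c1` is not yet measured. It differs from compound 3 in one place: 3,5-dimethoxyphenyl in place of isopropyl on an amide-type nitrogen. Because compound 1 with 16000 nM and compound 2 with 11400 nM sit below compound 3, a modest fall in the number is expected, though the change here is not the same as theirs. Compound 4 is therefore estimated at 20000 nM, with a range from 5000 nM to 80000 nM. The expected step is a 3.2-fold lower number from compound 3 to compound 4 (0.50 log units; beyond the scatter).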

Compound 4, half-maximal inhibitory concentration: 52900 nM
Compound 4: middle estimate off by 2.6-fold (0.42 log units), on the low side; the range from low to high includes it.
By their numbers in this assay, from the lowest: compounds 2 and 1 (each within the scatter of the next); then compounds 4 and 3 (each within the scatter of the next).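

Among the compounds shown here, this is the first single change that can be read at this position: in this assay, 3,5-dimethoxyphenyl in place of isopropyl on the amide-type nitrogen gives a 1.2-fold lower number from compound 3 to compound 4 (0.08 log units; within the scatter). On this core, therefore, replacing a group of 3 heavy atoms and no ring with one of 10 heavy atoms, including a six-membered aromatic ring, leaves the number indistinguishable from that of compound 3. Nothing available here accounts for this result.

As far as these compounds go, whether a chain ending in an amine or a carboxylic acid on the same nitrogen would shift the number remains open. So does whether 3,5-dimethoxyphenyl would give a similar result on the core of compound 1.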